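From piperidin-1-yl to 4-(methylsulfonyl)piperazin-1-yl in compound 3

The source may hold more compounds than are shown below. What is called first, only, known or untested is meant among the compounds shown, and "the series" means these compounds.

Measured in a functional assay on MV4-11 cells (Homo sapiens) for inhibition, read by luminescence, with a stated time of 72 h; a higher number here means a weaker inhibitor, a lower number a stronger inhibitor:
compound 1 `CCN1C(=O)COc2c(CN3CCN(C(C)C)CC3)cc(Nc3ncc(F)c(-c4ccc(F)cc4OC)n3)cc21` gives 149 nM
compound 2 `CCN1C(=O)COc2c(CN3CCCCC3)cc(Nc3ncc(F)c(-c4ccc(F)cc4OC)n3)cc21` gives 50 nM

Compound 2 holds the lower of the two numbers. Compound 3 `CCN1C(=O)COc2c(CN3CCN(S(C)(=O)=O)CC3)cc(Nc3ncc(F)c(-c4ccc(F)cc4OC)n3)cc21` departs from compound 2 at one place (4-(methylsulfonyl)piperazin-1-yl in place of piperidin-1-yl on a saturated chain carbon bound to an aromatic carbon). Going by the values given here, the only measured step at that place is a 3.0-fold lower number from compound 1 to compound 2 (0.47 log units; beyond the scatter), a modest one, which puts piperidin-1-yl in place of 4-isopropylpiperazin-1-yl. Read in reverse, it points to a similarly modest rise in this assay on returning to a piperazine, although no methylsulfonyl compound has been measured. The expected change is a 2.4-fold higher number from compound 2 to compound 3 (0.38 log units; beyond the scatter) on this single precedent. Compound 3 is estimated at 120 nM, with an expected range of 45 nM to 320 nM overall.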

Compound 3, half-maximal inhibitory concentration: 15 nM
Compound 3: middle estimate off by 8.0-fold (0.90 log units), on the high side, outside the stated range (below it).
By their numbers in this assay, from the lowest: compound 3; then compound 2; then compound 1.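

In this assay, going by these compounds alone, a piperazine at this position need not cost activity: the change to 4-(methylsulfonyl)piperazin-1-yl gives a 3.3-fold lower number from compound 2 to compound 3 (0.52 log units; beyond the scatter) and so reverses the direction that the single earlier step had suggested. With the piperazine kept, methylsulfonyl in place of isopropyl on the amine nitrogen in the ring gives a 9.9-fold lower number from compound 1 to compound 3 (1.00 log units; beyond the scatter), so among these compounds the group on that nitrogen matters greatly. Nothing available explains this gain.

Still open, on these data alone, is whether an acetyl or methyl group on that nitrogen would sit nearer compound 3 or compound 1. A morpholine in place of the whole ring is equally unresolved.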